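The source may hold more compounds than are shown below. What is called first, only, known or untested is meant among the compounds shown, and "the series" means these compounds.

Compound 1 `Oc1ccc(N2CCN(CC(O)COc3cccc4ccccc34)CC2)c(O)c1` and compound 2 `Oc1ccccc1N1CCN(CC(O)COc2cccc3ccccc23)CC1` share one core and differ only by a hydroxy on an aromatic carbon. In an ADME assay on PNT1A cells (Homo sapiens) for cytotoxicity, read by MTT assay, with a stated time of 48 h (on this read-out higher numbers stand for weaker inhibition and lower numbers for stronger inhibition), compound 1 gives 29900 nM, and compound 2 gives 22200 nM. Among the compounds with values here, compound 1 stands at one end of this pair, with compound 2 its only neighbour, and the step of a 1.3-fold lower number from compound 1 to compound 2 (0.13 log units; within the scatter) is too small to separate the two. Compound 3 `Oc1ccc(N2CCN(CC(O)COc3ccc(O)c4ccccc34)CC2)c(O)c1` differs from compound 1 by hydroxy in place of hydrogen on an aromatic carbon. Within the data shown here, no measured step adds a hydroxy at this place, so the only guide is the one measured change of a hydroxy on an aromatic carbon, which stayed within the scatter. A step of a 1.0-fold higher number from compound 1 to compound 3 (0.00 log units; within the scatter) is therefore expected, meaning no change beyond the scatter, because a 1.3-fold lower number from compound 1 to compound 2 (0.13 log units; within the scatter) lay within it. Compound 3 is estimated at 30000 nM, with a likely range from 12000 nM to 75000 nM.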

Compound 3, half-maximal inhibitory concentration: 17100 nM
Beside the measured number, compound 3's estimate is 1.8-fold (0.24 log units) above it; measured number inside the range.
By their numbers in this assay, from the lowest: compounds 3, 2 and 1 (each within the scatter of the next).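

Compound 3 carries its new hydroxy on an aromatic carbon of the fused two-ring system, para to a large group, a place the earlier pair did not touch. In this assay, this addition gives a 1.7-fold lower number from compound 1 to compound 3 (0.24 log units; within the scatter), so the cytotoxicity read-out does not separate the two compounds. The earlier pair showed this for a hydroxy at another aromatic carbon, and compound 3 now shows the same for this new place, though no measurement here explains the result.

From the compounds shown here alone, whether a methoxy, an amine or a carboxylic acid at this same place would move the number beyond the scatter remains open. Also open, going by these compounds, is whether this hydroxy would give the same result on the core of compound 2, which has one hydroxy fewer.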